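The compounds below may be only part of what the source reports. "The series", "measured", "known", "first", "only" and "open" are said of these compounds alone.

In a functional assay on HL-60 cells (Homo sapiens) for antiproliferative activity, read by sulforhodamine B assay, with a stated time of 72 h (on this read-out lower numbers stand for stronger inhibition and higher numbers for weaker inhibition), compound 3 `COc1cccc(NC(=S)N/N=C/c2ccc3ccccc3n2)c1` gives 71200 nM and compound 1 `S=C(N/N=C/c1ccc2ccccc2n1)Nc1cccc(Br)c1` gives 53800 nM, two values within the scatter of each other. Compound 2 `NC(=S)N/N=C/c1ccc2ccccc2n1` gives > 100000 nM, which is a limit of the assay and not a number. Compound 4 `Fc1cccc(NC(=S)N/N=C/c2ccc3ccccc3n2)c1` has fluoro in place of methoxy on an aromatic carbon, meta to a large group: fluoro in place of methoxy on an aromatic carbon. The nearest measured swap, methoxy in place of bromo, gave a 1.3-fold higher number from compound 1 to compound 3 (0.12 log units; within the scatter), within the scatter. Hydrogen in place of 3-bromophenyl gave an at least 1.8-fold higher number from compound 1 to compound 2 (0.26 log units; that floor lies within the scatter), and 3-methoxyphenyl in place of hydrogen gave an at least 1.4-fold lower number from compound 2 to compound 3 (0.14 log units; that floor lies within the scatter), both floors within the scatter. No step beyond the scatter is therefore expected in this assay, and the expected step is a 1.1-fold lower number from compound 3 to compound 4 (0.04 log units; within the scatter). Compound 4 is estimated at 65000 nM, with an expected range of 30000 nM to 100000 nM.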

Compound 4, half-maximal inhibitory concentration: 43800 nM
Compound 4: middle estimate off by 1.5-fold (0.17 log units), on the high side; the range from low to high includes it.
By their numbers in this assay, from the lowest: compounds 4, 1 and 3 (each within the scatter of the next). At a limit, above all of these: compound 2.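

Going by these compounds alone, at this aromatic carbon, meta to a large group, fluoro, methoxy and bromo cannot be told apart in this assay: fluoro in place of methoxy gave a 1.6-fold lower number from compound 3 to compound 4 (0.21 log units; within the scatter) and fluoro in place of bromo gave a 1.2-fold lower number from compound 1 to compound 4 (0.09 log units; within the scatter) with no step past the scatter. Placing 3-fluorophenyl on the amide-type nitrogen of compound 2 gave an at least 2.2-fold lower number from compound 2 to compound 4 (0.35 log units; beyond the scatter) as the only step shown that passes the scatter. Compound 2 stands at a limit and not at a number: the limit of > 100000 nM in this assay, at which 1 of the 4 values shown sits.

Going by these compounds, whether an amine or a carboxylic acid on this carbon would give a step beyond the scatter stays open.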